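Chloro to methyl on compound 2: expectation for cytotoxicity

The source may hold more compounds than are shown below. What is called first, only, known or untested is meant among the compounds shown, and "the series" means these compounds.

For the measured compounds named here, compound 1 `CC(=O)Oc1cc(Cl)ccc1C(=O)Nc1ncc([N+](=O)[O-])s1` and compound 2 `O=C(Nc1ncc([N+](=O)[O-])s1)c1ccc(-c2ccc(Cl)cc2)o1` share one core and two of the measured values so far. In an ADME assay on HEK-293T cells (Homo sapiens) for cytotoxicity, read by MTT assay, tested at 100 uM (on this read-out higher numbers stand for a weaker effect at the one concentration tested and lower numbers for a stronger effect), compound 1 gives 83.5% and compound 2 gives 74.1%. Compound 2 has the lowest of the two numbers, but its gap to compound 1 lies within the scatter, so the two read-outs are taken as equal. Compound 3 `Cc1ccc(-c2ccc(C(=O)Nc3ncc([N+](=O)[O-])s3)o2)cc1` differs from compound 2 by methyl in place of chloro on an aromatic carbon. Going by the values given here, no step between measured compounds covers this change, so the series itself shows nothing about its effect. Both measured compounds sit at a weak effect, and a swap of one heavy atom on the six-membered aromatic ring of carbon only gives no ground to expect more than the scatter: the estimated step of a number 1.9 percentage points higher from compound 2 to compound 3 (within the scatter) is small, with no direction. Compound 3 is therefore expected near 76%, between 62% and 90%.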

Compound 3, a percentage reported as activity, at one concentration (the size of the read-out at that concentration, not a potency): 91.5%
For compound 3 the middle estimate is 15.5 percentage points below the measured one; the whole stated range lies below it.
By their numbers in this assay, from the lowest: compounds 2, 1 and 3 (each within the scatter of the next, the first and the last beyond it).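

In this assay, the change from 4-chlorophenyl to 4-methylphenyl gives a number 17.4 percentage points higher from compound 2 to compound 3 (beyond the scatter), which moves the read-out towards a weaker effect. For the compounds shown here, this is the first single-place comparison, and it shows that the aromatic carbon para to a large group is sensitive to the exchange of one heavy atom, with methyl reading weaker than chloro at the one concentration tested. Nothing at hand accounts for the size or the direction of this step.

The compounds shown cannot separate a contribution from methyl entering from one from chloro leaving, since only these two groups appear at this carbon. As far as these compounds go, how hydrogen, a methoxy group, an amine or a carboxylic acid would read there remains open, as does whether the same exchange gives a similar step on another core.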